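The compounds below may be only part of what the source reports. "The series", "measured", "known", "first", "only" and "open" are said of these compounds alone.

In an assay on isolated protein (spleen, strain Sprague-Dawley) for antagonist activity at Alpha-1B adrenergic receptor (Rattus norvegicus), with a stated time of 20 min (a lower number here means tighter binding, a higher number weaker binding), compound 1 `COc1ccccc1N1CCN(CCCNC(=O)c2cc3cc(O)ccc3[nH]2)CC1` gives 155 nM, and compound 2 `COc1ccccc1N1CCN(CCCNC(=O)c2cc3cc(Cl)ccc3[nH]2)CC1` gives 257 nM. Within the data shown here, the only step between them, a 1.7-fold higher number from compound 1 to compound 2 (0.22 log units; within the scatter), leaves compound 2 with the higher of the two numbers, yet the gap falls within the scatter, so no order between the two can be claimed. Compound 3 `COc1ccccc1N1CCN(CCCNC(=O)c2cn(C)c3ccccc23)CC1` is built from compound 2 by a change at the carbonyl carbon: 1-methyl-1H-indol-3-yl in place of 5-chloro-1H-indol-2-yl on a carbonyl carbon. Among the measured compounds shown here, this differs in kind from the earlier step, which only exchanged one group on the aromatic carbon; no measured pair tells what the shift of the amide attachment and the loss of the ring hydrogen-bond donor do in this assay. The measured step was small, and nothing in the data points to a direction, so for compound 3 in this assay a step beyond the scatter is not expected with any confidence, though the larger change leaves more room for weaker binding; the expected step is a 1.6-fold higher number from compound 2 to compound 3 (0.19 log units; within the scatter). Compound 3 is therefore estimated to give 400 nM, within a range from 100 nM to 1600 nM.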

Compound 3, dissociation constant: 166 nM
Estimate against measurement, compound 3: 2.4-fold (0.38 log units) above; low and high end bracket the measured number.
By their numbers in this assay, from the lowest: compounds 1, 3 and 2 (each within the scatter of the next).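

Among these compounds, until now only one group on the aromatic carbon had been exchanged, whereas here the whole group on the carbonyl carbon changes, and in this assay the exchange of 5-chloro-1H-indol-2-yl for 1-methyl-1H-indol-3-yl gives a 1.5-fold lower number from compound 2 to compound 3 (0.19 log units; within the scatter) and so stays within the scatter. Set against the hydroxy-bearing group, the same entering group gives a 1.1-fold higher number from compound 1 to compound 3 (0.03 log units; within the scatter) and also stays within the scatter, so no order can be claimed among the three compounds. This position on the carbonyl carbon therefore accepts a different indolyl attachment, and an entering group without the hydrogen-bond donor of the leaving group, with no difference that can be read in this assay.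

Compound 3 carries the new attachment and the 1-methyl group at once, so the share of each cannot be separated. The compounds shown also leave open how an unsubstituted 1H-indol-3-yl or a plain phenyl on the carbonyl carbon would compare, and no supporting evidence is available to explain these numbers.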